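Working notes: octyl in place of 2-methylprop-1-en-1-yl

The source may report more compounds than this note shows. Statements on the series, on what has been measured and on what is new or still open speak of the compounds shown alone.

Measured so far:
Compound 1, `COc1ccc(-c2c(-c3ccccc3)sc(C(C)C)c2/C=C/[C@@H](O)C[C@@H](O)CC(=O)O)cc1`, gives 2430 nM in an assay on microsomes for inhibition of 3-hydroxy-3-methylglutaryl-coenzyme A reductase (Rattus norvegicus); on this read-out higher numbers stand for weaker inhibition and lower numbers for stronger inhibition.
Compound 2, `CC(C)=Cc1sc(C(C)C)c(/C=C/[C@@H](O)C[C@@H](O)CC(=O)O)c1-c1ccc(F)cc1`, gives 15 nM in this assay.

Compound 2 holds the lower of the two numbers in this assay; the number for compound 1 lies well above it, beyond the usual scatter. The two compounds differ in more than one place, so their gap cannot be assigned to any single change.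

Compound 3, `CCCCCCCCc1sc(C(C)C)c(/C=C/[C@@H](O)C[C@@H](O)CC(=O)O)c1-c1ccc(F)cc1`, differs from compound 2 in one place: octyl in place of 2-methylprop-1-en-1-yl on an aromatic carbon. Going by the values given here, no pair of measured compounds differing in a single place is available, so there is no measured step to anchor this change; the expectation rests on compound 2 alone. From the compounds shown here alone, the entering octyl chain is longer than the leaving group and has no double bond, and how this assay answers to such a change at this carbon is unknown. A moderate shift toward a higher number is expected, from compound 2 to compound 3 of a 3.0-fold higher number from compound 2 to compound 3 (0.48 log units; beyond the scatter), with a wide range in either direction. Compound 3 is expected to give 45 nM, between 10 nM and 250 nM.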

Compound 3, half-maximal inhibitory concentration: > 10000 nM
Compound 3: only a limit was reported; the forecaster's own chance of this, stated with the estimate: 3%; middle value at least 220-fold (2.34 log units) from the limit.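

Going by these compounds alone, this is the first single-place change that can be read: in this assay the step of an at least 660-fold higher number from compound 2 to compound 3 (2.82 log units; beyond the scatter) comes from octyl in place of 2-methylprop-1-en-1-yl on the aromatic carbon next to the ring sulfur, with the rest of the structure unchanged. Compound 3 gives > 10000 nM as a limit of the assay and not as a number. This carbon is therefore far from indifferent to the group it carries, even when both groups hold only carbon, and the size of the step can be read only as a bound, set by the limit reached here: the limit of > 10000 nM in this assay, at which 1 of the 3 values shown sits.

Octyl differs from 2-methylprop-1-en-1-yl both in its number of heavy atoms and in lacking the double bond, so it stays open which of the two differences goes with the change in the read-out. A saturated 2-methylpropyl group would hold the count of the leaving group without its double bond, and a longer alkenyl chain would keep the double bond, so either would help to tell these two differences apart at this carbon.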